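The compounds below may be only part of what the source reports. "The series", "measured", "known", "first", "only" and "open" are said of these compounds alone.

Measured so far:
compound 1 `C[C@@H](c1ccc(Cl)cc1)N1Cc2cncn2C(CC2(C)COC2)S1(=O)=O`: 35%
compound 2 `CC(C)CC1n2cncc2CN(C2CC2)S1(=O)=O`: 9%

In an assay on isolated protein for inhibition of Aromatase (Homo sapiens), tested at 1 uM (a higher number here means more inhibition at the concentration tested (going by the name of the read-out), a lower number less inhibition), compound 1 gives 35%, the higher of the two numbers recorded. Compound 2 gives 9%, and the gap between the two lies beyond the usual scatter. Within the data shown here, compound 1 and compound 2 differ in more than one place, so no single-change step is available to calibrate the next change against.

Compound 3 `C[C@@H](c1ccc(Cl)cc1)N1Cc2cncn2C(C[C@H](O)c2ccccc2)S1(=O)=O` differs from compound 1 by hydroxy(phenyl)methyl in place of 3-methyloxetan-3-yl on a saturated chain carbon bound to a saturated ring carbon. The group that enters carries one six-membered aromatic ring of carbon only and one hydrogen-bond donor, where the group that leaves carried a four-membered non-aromatic ring with one hetero atom and no donor.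

With nothing measured to anchor it, the step in this assay is expected to be modest and upward, close to the edge of the scatter: a number 10 percentage points higher from compound 1 to compound 3 (within the scatter). Compound 3 is accordingly estimated at 45%, expected to fall between 15% and 75%.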

Compound 3, a percentage reported as inhibition, at one concentration (the size of the read-out at that concentration, not a potency): 6%
The estimate for compound 3 lay 39 percentage points above the measured number, outside the stated range (below it).
By their numbers in this assay, from the lowest: compounds 3 and 2 (each within the scatter of the next); then compound 1.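

In this assay, among these compounds, hydroxy(phenyl)methyl in place of 3-methyloxetan-3-yl on a saturated chain carbon bound to a saturated ring carbon gives a number 29 percentage points lower from compound 1 to compound 3 (beyond the scatter), the only single-place comparison, showing that the read-out responds to the group at this position. The change swaps a four-membered non-aromatic ring without a donor for a six-membered aromatic ring with a hydrogen-bond donor and a defined stereocentre, so the step cannot be assigned to any one of these features. Nothing measured on these compounds accounts for the step.

Open, as far as these compounds go, is whether the loss follows the phenyl ring, the hydroxy group or the stereocentre. A benzyl group or a hydroxymethyl group at this place would separate the first two, and the opposite stereoisomer of hydroxy(phenyl)methyl would test the third.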